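Hydroxymethyl in place of propoxycarbonyl on an aromatic carbon

The compounds below may be only part of what the source reports. "The series", "measured", "known", "first", "only" and "open" are said of these compounds alone.

In a functional assay on cells (Platelet, Homo sapiens) for inhibition (on this read-out lower numbers stand for stronger inhibition and higher numbers for weaker inhibition), compound 1 `CCOC(=O)c1cccc(-c2n[nH]c3ccccc23)c1` gives > 10000 nM as a limit of the assay, not a number. Compound 2 `CCCOC(=O)c1ccc(-c2nn(Cc3ccccc3)c3ccccc23)cc1` gives > 10000 nM as a limit too. Compound 2 thus stands at the limit of > 10000 nM in this assay, at which 2 of the 2 values shown sit, and has no number of its own. Compound 3 `OCc1ccc(-c2nn(Cc3ccccc3)c3ccccc23)cc1` carries hydroxymethyl in place of propoxycarbonyl on an aromatic carbon para to a large group. For the measured compounds named here, no measured step shows what this change does in this assay and only a modest gain towards stronger inhibition is expected. The estimated step of an at least 1.2-fold lower number from compound 2 to compound 3 (0.09 log units; that floor lies within the scatter) is small, and another limit remains possible. For compound 3 the expected value is 8000 nM within an estimated range of 2000 nM to 30000 nM on this read-out.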

Compound 3, half-maximal inhibitory concentration: > 10000 nM
Compound 3 ended at the assay's limit; the forecaster's own chance of this, stated with the estimate: 45%; middle value at least 1.2-fold (0.09 log units) away from the limit.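

No step can be read between compound 2 and compound 3, as each gives a limit of the assay and not a number. Both stand at the same limit: the limit of > 10000 nM in this assay, at which 3 of the 3 values shown sit.

The compounds shown leave open whether hydroxymethyl in place of propoxycarbonyl changes inhibition at all.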